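Oximes with two halogenated rings: swapping chloro for fluoro

The source may hold more compounds than are shown below. What is called first, only, known or untested is meant among the compounds shown, and "the series" means these compounds.

Measured so far:
compound 1, `O/N=C(\C=C\c1ccc(F)cc1)c1ccc(Cl)cc1`: 11500 nM
compound 2, `O/N=C(\C=C\c1ccc(Cl)cc1)c1ccc(Br)cc1`: 24700 nM

Both compounds were tested in an ADME assay on cells (Mus musculus, strain Balb/c) for cytotoxicity, read by MTT assay, with a stated time of 48 h; on this read-out higher numbers stand for lower toxicity in this test and lower numbers for higher toxicity in this test. Compound 1 gives 11500 nM in this assay. Compound 2 gives 24700 nM in this assay, the highest of the two numbers; its nearest neighbour is compound 1, whose number is lower by a gap that lies beyond the usual scatter of this measurement.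

The next compound to be tested is compound 3, `O/N=C(\C=C\c1ccc(F)cc1)c1ccc(Br)cc1`. It differs from compound 2 in a single place: fluoro in place of chloro on an aromatic carbon. Going by the values given here, no step between two measured compounds shows the effect of this exchange on its own, so what follows is an expectation, not a measured trend.

Since compound 1 carries the fluoro group at the same place and gives 11500 nM, while compound 2 gives 24700 nM, compound 3 is expected to land between the two. The step of a 1.5-fold lower number from compound 2 to compound 3 (0.16 log units; within the scatter) is expected to be small and downward, close to the edge of the scatter. Compound 3 is therefore estimated at 17000 nM in this assay, with a likely range from 8000 nM to 38000 nM.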

Compound 3, half-maximal cytotoxic concentration: 20300 nM
Beside the measured number, compound 3's estimate is 1.2-fold (0.08 log units) below it, within the range that was stated.
By their numbers in this assay, from the lowest: compounds 1, 3 and 2 (each within the scatter of the next, the first and the last beyond it).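

Going by these compounds alone, the first single exchange at this position can now be read in this assay: fluoro in place of chloro on an aromatic carbon gives a 1.2-fold lower number from compound 2 to compound 3 (0.09 log units; within the scatter), so in this pair the two halogens cannot be told apart by this test. The second exchange, which brings in bromo and removes chloro, gives a 1.8-fold higher number from compound 1 to compound 3 (0.25 log units; within the scatter), so this pair cannot be told apart either, and neither single swap stands out from the ordinary spread of repeated measurements. Nothing in the available data says why these halogen swaps leave the number so little moved.

Going by these compounds, all three compounds carry only halogens as ring substituents, so it remains open whether the number would stay in the same region with a group of another kind on this aromatic carbon, such as an amine, a methoxy group or a carboxylic acid. The compounds shown also all keep the free oxime hydroxyl, so they leave open what a methyl ether at that oxygen would do in this test.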